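This account rests on a few compounds, and the source may have more. Where it says the series, first, only, none or still open, it means among the compounds named here.

Of the compounds shown here, three of one series have been measured in a functional assay on a cell-free system (plasma, Homo sapiens), with a stated time of 3 min; on this read-out lower numbers stand for stronger inhibition and higher numbers for weaker inhibition. Compound 1 `Cc1cccc([C@@H](O)C(=O)N2N=CC[C@H]2C(=O)NCc2cc(Cl)ccc2-n2cnnn2)c1` gives 830 nM. Compound 2 `O=C([C@H](O)c1ccccc1)N1CC[C@@H]2C[C@@]21C(=O)NCc1cc(Cl)ccc1-n1cnnn1` gives 1100 nM, and compound 3 `O=C(NCc1cc(Cl)ccc1-n1cnnn1)[C@@H]1C[C@H]2C[C@H]2N1C(=O)[C@H](O)c1cccc(F)c1` gives 1100 nM; compound 2 and compound 3 share the same digits, and the gap from compound 2 to compound 1 lies within the usual scatter, so none of the three can be set apart from the others.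

Compound 4 `CC(C)(C)[C@@H](O)C(=O)N1CC[C@@H]2C[C@@]21C(=O)NCc1cc(Cl)ccc1-n1cnnn1` has not yet been measured. Relative to compound 2 the change is tert-butyl in place of phenyl on a saturated chain carbon bound to a carbonyl carbon and an oxygen on a saturated carbon. Going by the values given here, no measured pair shows a step of this kind, so the expectation rests on the change alone. A moderate step toward a higher number, beyond the scatter, is expected from compound 2 to compound 4, a 2.7-fold higher number from compound 2 to compound 4 (0.44 log units; beyond the scatter). Compound 4 is therefore estimated at 3000 nM, with a range from 1000 nM to 10000 nM.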

Compound 4, half-maximal inhibitory concentration: 1500 nM
The estimate for compound 4 lay 2.0-fold (0.30 log units) above the measured number, within the range that was stated.
By their numbers in this assay, from the lowest: compounds 1, 2, 3 and 4 (each within the scatter of the next).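

In this assay replacing phenyl with tert-butyl gives a 1.4-fold higher number from compound 2 to compound 4 (0.13 log units; within the scatter) and so does not separate the two groups at this position, on a saturated chain carbon bound to a carbonyl carbon and an oxygen on a saturated carbon. Within this pair, the six-membered aromatic ring is therefore not shown to be required. No evidence bearing on this result is available. The compounds shown leave open how an amine, a carboxylic acid or a longer chain would read in place of tert-butyl.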